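The compounds below may be only part of what the source reports. "The series", "measured", "known", "first", "only" and "open" are said of these compounds alone.

Three compounds share one core and differ only in the ring attached to the sulfonyl sulfur. Compound 1 `O=C(c1ccc(OCCCN2CC[C@H](NS(=O)(=O)c3cccc(F)c3)C2)cc1)C1CC1` gives 1600 nM in an assay on isolated protein for binding affinity to histamine H2 receptor (Homo sapiens); a higher number here means a weaker inhibitor, a lower number a stronger inhibitor. Compound 2 `O=C(c1ccc(OCCCN2CC[C@H](NS(=O)(=O)c3ccccc3F)C2)cc1)C1CC1` gives 1550 nM, and compound 3 `O=C(c1ccc(OCCCN2CC[C@H](NS(=O)(=O)c3ccccc3)C2)cc1)C1CC1` gives 1200 nM, the smallest of the three numbers, although the steps of a 1.3-fold lower number from compound 1 to compound 3 (0.12 log units; within the scatter) and a 1.3-fold lower number from compound 2 to compound 3 (0.11 log units; within the scatter) both lie within the scatter. Compound 4 `CC(C)(C)c1ccc(S(=O)(=O)N[C@H]2CCN(CCCOc3ccc(C(=O)C4CC4)cc3)C2)cc1` carries the change (tert-butyl in place of hydrogen on an aromatic carbon), para to a large group. Among the measured compounds shown here, no measured step involves tert-butyl; the measured steps only swap fluoro for hydrogen, and they show that such small changes on this ring moved nothing beyond the scatter. Compound 4 is therefore expected to give 1000 nM, within a range of 350 nM to 3000 nM, a step of a 1.2-fold lower number from compound 3 to compound 4 (0.08 log units; within the scatter) that is estimated to stay within the scatter.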

Compound 4, inhibition constant: 730 nM
The estimate for compound 4 lay 1.4-fold (0.14 log units) above the measured number, within the range that was stated.
By their numbers in this assay, from the lowest: compounds 4, 3, 2 and 1 (each within the scatter of the next, the first and the last beyond it).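

In this assay, the tert-butyl step gives a 1.6-fold lower number from compound 3 to compound 4 (0.22 log units; within the scatter), so a group of four heavy atoms at this place, para to a large group, stays within the scatter of the unsubstituted phenyl. Against the fluorinated rings, the steps of a 2.1-fold lower number from compound 2 to compound 4 (0.33 log units; beyond the scatter) and a 2.2-fold lower number from compound 1 to compound 4 (0.34 log units; beyond the scatter) are modest, yet they are the first here to pass beyond the scatter. No measurement offered here explains this result. Still open, on these data alone, is how an amine or a carboxylic acid at this same place would read in this assay.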